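The source may report more compounds than this note shows. Statements on the series, on what has been measured and on what is new or still open speak of the compounds shown alone.

Measured so far:
compound 1 `C[C@@]1(c2cc(NC(=O)c3coc(CF)n3)ccc2F)C=C(CF)OC(N)=N1` — 2.2
compound 2 `C[C@@]1(c2cc(NC(=O)c3cnc(OCF)cn3)ccc2F)C=C(CF)OC(N)=N1` — 2.6
compound 3 `CC1=C[C@@](C)(c2cc(NC(=O)c3ccc(C#N)cn3)ccc2F)N=C(N)O1` — 2.2

In a physicochemical assay for lipophilicity, read by HPLC, in phosphate buffer, measured as octanol-water partition, with a stated time of 1 h, at pH 7.4 (a higher number here means a more lipophilic compound, a lower number a more polar compound), compound 1 gives 2.2, level with compound 3 at the digits shown, the two together the lowest of the three numbers; compound 2 stands furthest from it, and the one measured step on the shared core, a number 0.40 log units higher from compound 1 to compound 2 (beyond the scatter), is beyond the scatter and modest in size.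

Compound 4 `C[C@@]1(c2cc(NC(=O)c3ncc(C#N)cc3Cl)ccc2F)C=C(CF)OC(N)=N1` is not yet measured. It differs from compound 1 in one place: 3-chloro-5-cyanopyridin-2-yl in place of 2-(fluoromethyl)-1,3-oxazol-4-yl on a carbonyl carbon. Going by the values given here, no measured step covers this exact exchange. The step from compound 1 to compound 2 shows that swapping the five-membered heteroaryl amide for a six-membered one on this core moved the value upward in this assay. Compound 3 carries a cyanopyridine amide, but on a core that differs from that of compound 1 as well, so only its value can be read, and it sits level with compound 1. An upward step, larger than that from compound 1 to compound 2, is expected, a number 0.60 log units higher from compound 1 to compound 4 (beyond the scatter). For compound 4 the estimate in this assay is 2.8, with a range from 2.4 to 3.3.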

Compound 4, distribution coefficient: 2.5
Compound 4: middle estimate off by 0.30 log units, on the high side; the measured number falls inside the stated range.
By their numbers in this assay, from the lowest: compounds 1, 3, 4 and 2 (each within the scatter of the next, the first and the last beyond it).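

On the shared core, the amide position takes 3-chloro-5-cyanopyridin-2-yl with a number 0.30 log units higher from compound 1 to compound 4 (within the scatter) in this assay, so this exchange, unlike the one to 5-(fluoromethoxy)pyrazin-2-yl, does not separate from compound 1 beyond the scatter. The same group also gives a number 0.10 log units lower from compound 2 to compound 4 (within the scatter), which places compound 4 within the scatter of both compounds, although compound 1 and compound 2 themselves stand apart beyond it. A six-membered aromatic ring at this position therefore does not by itself carry a step beyond the scatter, and no measurement shown explains the result.

On these data alone, the separate contributions of the chlorine and the nitrile on the pyridine remain open, as they appear only together on this core. Also open, as far as these compounds go, is how this assay would read for a ring carrying an amine or a carboxylic acid at this position.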